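The source may report more compounds than this note shows. Statements on the series, on what has been measured and on what is new or still open speak of the compounds shown alone.

Measured in an ADME assay on Caco-2 cells (Homo sapiens) for permeability, read by LC-MS, in the apical to basolateral direction, with a stated time of 60 min, at pH 6.5; on this read-out higher numbers stand for higher permeability and lower numbers for lower permeability:
- compound 1 `O=C(NCc1cc(Cl)ccc1-n1cnnn1)[C@@H]1CC=NN1C(=O)[C@H](O)c1ccccc1`: 7 10^-6 cm/s
- compound 2 `CC(C)(C)C[C@@H](O)C(=O)N1[C@H](C(=O)NCc2cc(Cl)ccc2-n2cnnn2)C[C@@H]2C[C@@H]21`: 25 10^-6 cm/s

Compound 1 holds the lower of the two numbers, and the gap to compound 2 lies beyond the scatter. Compound 3 `COC(C)(C)[C@@H](O)C(=O)N1N=CC[C@H]1C(=O)NCc1cc(Cl)ccc1-n1cnnn1` is next, with the change 1-methoxy-1-methylethyl in place of phenyl on a saturated chain carbon bound to a carbonyl carbon and an oxygen on a saturated carbon. Among the measured compounds shown here, no measured pair differs in one place, so nothing sizes this change directly. In this assay, no step beyond the scatter is expected, and the estimated step is no change at the digits printed from compound 1 to compound 3 (within the scatter). The expected value for compound 3 is 7 10^-6 cm/s, within an estimated range of 3 10^-6 cm/s to 16 10^-6 cm/s.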

Compound 3, apparent permeability: 1.7 10^-6 cm/s
Beside the measured number, compound 3's estimate is 4.1-fold (0.61 log units) above it; measured number outside the range, below it.
By their numbers in this assay, from the lowest: compound 3; then compound 1; then compound 2.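

In this assay, among the compounds shown here, this saturated chain carbon proves sensitive to its substituent: 1-methoxy-1-methylethyl in place of phenyl gives a 4.1-fold lower number from compound 1 to compound 3 (0.61 log units; beyond the scatter) and is the first change that can be sized. For the compounds shown here, that change removes the six-membered aromatic ring and adds one hydrogen-bond acceptor, and the single step cannot separate the two differences. Nothing measured here bears on the cause of the step.

Open, from the compounds shown here alone, is whether tert-butyl or cyclohexyl, which carry no ether oxygen, would sit nearer compound 1 or compound 3. Also open, going by these compounds, is whether this change gives a step of similar size on the core of compound 2.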